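Chloro in place of methoxy: cytotoxicity notes

A few compounds are considered here, and "the series" means these few. Any claim that something is new, unique, unknown or untested is made for them only; others in the source may bear on it.

In an ADME assay on BHK-21 cells (Mesocricetus auratus) for cytotoxicity, read by MTT assay, with a stated time of 96 h (on this read-out lower numbers stand for higher toxicity in this test and higher numbers for lower toxicity in this test), compound 1 (`COc1ccc(/N=N/N2CCCC2)cc1`) gives >= 100000 nM, which is a limit of the assay and not a number. Compound 2 (`Fc1ccc(F)c(/N=N/N2CCCC2)c1`) gives > 100000 nM, which is also a limit. Going by the values given here, compound 3 (`O=C1CCN(/N=N/c2ccccc2)CC1`) gives 90000 nM, the only true number in the set. Compound 1 therefore has a limit and no exact position.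

Compound 4 (`Clc1ccc(/N=N/N2CCCC2)cc1`) is the next entry. It has chloro in place of methoxy on an aromatic carbon, para to a group of 7 heavy atoms: chloro in place of methoxy on an aromatic carbon. Among the compounds with values here, no measured pair isolates a single change, so the size of this step has no direct precedent. None beyond the usual scatter is expected, with a small shift toward lower numbers in this assay as the only likely direction. This expectation leans on compound 3 at 90000 nM, although its structure differs more widely. The expected step is an at least 1.1-fold lower number from compound 1 to compound 4 (0.04 log units; that floor lies within the scatter). For compound 4 the estimated value is 90000 nM, with an expected range of 35000 nM to 200000 nM.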

Compound 4, half-maximal cytotoxic concentration: > 100000 nM
Compound 4 ended at the assay's limit; the forecaster's own chance of this, stated with the estimate: 45%; at least 1.1-fold (0.04 log units) between middle value and limit.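

In this assay compound 1 and compound 4 both end at a limit and not at a number, so the step for chloro in place of methoxy cannot be read. The compounds shown leave open whether this change shifts the read-out at all.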